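This account rests on a few compounds, and the source may have more. Where it says the series, first, only, none or still open, it means among the compounds named here.

The measured compounds are compound 1 `CC(C)(C)[Si](C)(C)O[C@@H]1CCCO[C@@H]1CO`, compound 2 `CC(C)(C)[Si](C)(C)O[C@@H]1CCCO[C@@H]1COCC(=O)O` and compound 3 `CC(C)(C)[Si](C)(C)O[C@@H]1CCCO[C@@H]1COCC(=O)OCc1ccccc1`.

In a functional assay on SW1573 cells (Homo sapiens) for antiproliferative activity, read by sulforhodamine B assay, with a stated time of 48 h (a higher number here means a weaker inhibitor of growth, a lower number a stronger inhibitor of growth), compound 1 gives only a limit, > 100000 nM. Compound 2 likewise gives only a limit, > 100000 nM. Among the compounds with values here, compound 3 gives 29000 nM, the only number among the three, since (the limit of > 100000 nM in this assay, at which 2 of the 3 values shown sit). The step that the two limits leave unreadable from compound 1 to compound 2 cannot be read. Within the data shown here, the step of an at least 3.4-fold lower number from compound 2 to compound 3 (0.53 log units; beyond the scatter) is the one readable change.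

Compound 4 `O=C(COC[C@H]1OCCC[C@H]1O)OCc1ccccc1` differs from compound 3 by a hydrogen atom in place of a group of 7 heavy atoms (6 carbon, 1 silicon; no ring), on an oxygen on a saturated carbon. Among the measured compounds shown here, no measured step touches this position, so the two steps give no direct guide. Compound 4 is expected at 60000 nM, within 15000 nM to 200000 nM. The expected step of a 2.1-fold higher number from compound 3 to compound 4 (0.32 log units; beyond the scatter) in this assay is therefore a guess of a somewhat weaker inhibitor, with a fair chance that only a limit results.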

Compound 4, concentration for 50% growth inhibition: > 100000 nM
Compound 4 ended at the assay's limit; the forecaster's own chance of this, stated with the estimate: 40%; at least 1.6-fold (0.22 log units) between middle value and limit.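

In this assay, within the data shown here, this is the first measured change on the oxygen on a saturated carbon, and a hydrogen atom in place of the group of 7 heavy atoms (6 carbon, 1 silicon; no ring) gives an at least 3.4-fold higher number from compound 3 to compound 4 (0.53 log units; beyond the scatter). Among these compounds, compound 4 keeps the benzyl group, so benzyl alone does not give a measurable number here; compound 3, with both groups, is the only compound that does.

From the compounds shown here alone, how much weaker compound 4 really is stays open: the limit of > 100000 nM in this assay, at which 3 of the 4 values shown sit. Also open is whether a methyl group or an acetyl group on this oxygen would give a measurable number.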